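A few compounds are considered here, and "the series" means these few. Any claim that something is new, unique, unknown or untested is made for them only; others in the source may bear on it.

Measured in an ADME assay on microsomes (Homo sapiens) for metabolic stability; on this read-out lower numbers stand for slow clearance and higher numbers for fast clearance:
- compound 1 `Cc1cc(C(F)(F)F)c2cccc(OCc3c(Cl)ccc(S(=O)(=O)N4CCC[C@H]4C(N)=O)c3Cl)c2n1`: 167 mL/min/kg
- compound 2 `Cc1cc(C(F)(F)F)c2cccc(OCc3c(Cl)ccc(S(=O)(=O)N4CCC[C@H]4C(=O)O)c3Cl)c2n1`: 8.33 mL/min/kg
- compound 3 `Cc1cc(C(F)(F)F)c2cccc(OCc3c(Cl)ccc(S(=O)(=O)N4CCCCC4)c3Cl)c2n1`: 233 mL/min/kg

Compound 3 stands at the fast-clearance end of this small set, level with compound 1: a 1.4-fold higher number from compound 1 to compound 3 (0.14 log units; within the scatter) is a difference that stays within the scatter. Compound 2 is far away, as a 28-fold higher number from compound 2 to compound 3 (1.45 log units; beyond the scatter) shows.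

The next compound is compound 4 `Cc1cc(C(F)(F)F)c2cccc(OCc3c(Cl)ccc(S(=O)(=O)N4CCC(C#N)CC4)c3Cl)c2n1`. It keeps everything in compound 3 except one position, where the piperidin-1-yl group becomes 4-cyanopiperidin-1-yl: cyano in place of hydrogen on a saturated ring carbon. This is cyano in place of hydrogen on a saturated ring carbon, three ring bonds from the ring nitrogen.

Among the compounds with values here, no measured step makes this exact change, so the evidence is indirect. The other steps alter the same group on the sulfonyl sulfur. Among them, a 20-fold lower number from compound 1 to compound 2 (1.30 log units; beyond the scatter) is large, and it creates the carboxy group of compound 2. Compound 4 gains no carboxy group, so the nearer guide is a 1.4-fold higher number from compound 1 to compound 3 (0.14 log units; within the scatter), a step within the scatter. A step within the scatter is therefore expected in this assay, perhaps leaning towards a lower number.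

The expected change is a 1.4-fold lower number from compound 3 to compound 4 (0.14 log units; within the scatter).

For compound 4 the estimated clearance is 170 mL/min/kg, with an expected range from 80 mL/min/kg to 300 mL/min/kg.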

Compound 4, clearance: 433 mL/min/kg
Compound 4: the middle estimate sits 2.5-fold (0.41 log units) below what was measured; the measured number lies above the stated range.
By their numbers in this assay, from the lowest: compound 2; then compounds 1, 3 and 4 (each within the scatter of the next, the first and the last beyond it).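

In this assay, the change at this position is a 1.9-fold higher number from compound 3 to compound 4 (0.27 log units; within the scatter), so a cyano group on this saturated ring carbon, three ring bonds from the ring nitrogen, leaves the number level with that of the unsubstituted ring. Within the data shown here, this is the first substituent seen at this ring carbon, and compound 4 stays with the fast-clearance compounds: a 2.6-fold higher number from compound 1 to compound 4 (0.41 log units; beyond the scatter) is a modest step, while a 52-fold higher number from compound 2 to compound 4 (1.72 log units; beyond the scatter) is a large one that leaves compound 2 alone at the slow-clearance end. Nothing measured here bears on the reason for this result.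

The compounds shown leave open whether a different group on the same ring carbon, such as a hydroxyl, an aminomethyl group or a longer chain ending in an amine, would move the number beyond the scatter. They also leave open whether the low number of compound 2 belongs to the carboxy group alone, since that group appears here only on the ring of compound 2 and never on the six-membered ring of compound 3.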